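This account rests on a few compounds, and the source may have more. Where it says the series, first, only, none or still open, it means among the compounds named here.

Values measured so far in an ADME assay on HeLa cells (Homo sapiens) for cytotoxicity, read by MTT assay; on this read-out lower numbers stand for stronger inhibition and higher numbers for weaker inhibition:
Compound 1 `COc1ccc(C[C@H]2COC(=O)[C@@H]2Cc2ccc(OCc3cn(-c4ccc(F)cc4)nn3)c(OC)c2)cc1OC`: >= 600000 nM, a limit of the assay.
Compound 2 `COc1ccc(C[C@H]2COC(=O)[C@@H]2Cc2ccc(OCc3cn(Cc4ccc(Cl)cc4)nn3)c(OC)c2)cc1OC`: 242000 nM.
Compound 3 `COc1ccc(C[C@H]2COC(=O)[C@@H]2Cc2ccc(OCc3cn(-c4ccc(C)cc4)nn3)c(OC)c2)cc1OC`: >= 600000 nM, a limit of the assay.

Among the compounds with values here, compound 3 stands at a limit, >= 600000 nM, and so offers no exact number to step from. Compound 4 `COc1ccc(C[C@H]2COC(=O)[C@@H]2Cc2ccc(OCc3cn(Cc4ccccc4Cl)nn3)c(OC)c2)cc1OC` differs from it in one place, with 2-chlorobenzyl in place of 4-methylphenyl on an aromatic nitrogen. Within the data shown here, two measured steps bear on this change. Putting 4-chlorobenzyl in place of 4-fluorophenyl gave an at least 2.4-fold lower number from compound 1 to compound 2 (0.39 log units; beyond the scatter), and putting 4-methylphenyl in place of 4-chlorobenzyl gave an at least 2.4-fold higher number from compound 2 to compound 3 (0.39 log units; beyond the scatter). Of these three compounds, only compound 2, at 242000 nM, carries a benzyl group, and only it gives a number rather than a limit. Among the measured compounds shown here, no measured compound carries 2-chlorobenzyl, so carrying this result over from 4-chlorobenzyl is uncertain. In this assay, a modest step to a lower number is therefore expected, much like the two measured steps, although compound 4 could also end up at a limit. The expected step is an at least 2.4-fold lower number from compound 3 to compound 4 (0.38 log units; beyond the scatter). For compound 4, the estimated value is 250000 nM, with an expected range from 100000 nM to 600000 nM.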

Compound 4, half-maximal inhibitory concentration: 84500 nM
Compound 4: the middle estimate sits 3.0-fold (0.47 log units) above what was measured; measured number below the stated range.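

In this assay, exchanging 4-chlorobenzyl for 2-chlorobenzyl gave a 2.9-fold lower number from compound 2 to compound 4 (0.46 log units; beyond the scatter), so on this aromatic nitrogen the place of the chlorine on the benzyl ring changes the result, which a single benzyl compound could not show. Against the groups without a chain carbon, 2-chlorobenzyl gave an at least 7.1-fold lower number from compound 3 to compound 4 (0.85 log units; beyond the scatter) and an at least 7.1-fold lower number from compound 1 to compound 4 (0.85 log units; beyond the scatter), and the two chlorobenzyl compounds are now the only ones of the four with exact numbers, with no compound shown going against this. Those two steps give only a bound on their size, because each starts from a limit of the assay: the limit of >= 600000 nM in this assay, at which 2 of the 4 values shown sit.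

The compounds shown leave open whether the chlorine or the chain carbon carries the difference, since a plain benzyl group and a 4-chlorophenyl group on the same nitrogen would be needed to separate the two. Also open, as far as these compounds go, is how a longer chain ending in the same chlorinated ring, or an amine or a carboxylic acid on that ring in place of the chlorine, would read in this assay.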